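The compounds below may be only part of what the source reports. "The series", "measured", "known", "first", "only" and "open" are said of these compounds alone.

Measured compounds:
compound 1, `O=C1COc2ccc(-c3cnc4ccccc4c3)cc2N1c1ccccc1`: > 40000 nM
compound 2, `COc1ncc(-c2ccc3c(c2)N(c2ccc(Cl)cc2)C(=O)CO3)cc1NS(=O)(=O)c1ccc(F)cc1`: 19200 nM

In a functional assay on HCT-116 cells (Homo sapiens) for antiproliferative activity, read by MTT assay, with a stated time of 72 h (on this read-out lower numbers stand for stronger inhibition and higher numbers for weaker inhibition), compound 1 gives > 40000 nM; this is a limit of the assay and not a number, so compound 1 stands at the weak end of what is shown, without a measured potency (the limit of > 40000 nM in this assay, at which 1 of the 2 values shown sits). Compound 2 gives 19200 nM in this assay, a number rather than a limit. Among the measured compounds shown here, no step between compound 1 and compound 2 is counted here; their two values show only that one is a number and the other a limit.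

Compound 3, `O=C1COc2ccc(-c3cnc4ccccc4c3)cc2N1c1ccc(F)cc1`, is still to be measured. It differs from compound 1 by fluoro in place of hydrogen on an aromatic carbon. For the measured compounds named here, no measured step of this kind is available, so the expectation is for no change beyond the usual scatter; the expected step is a number no higher from compound 1 to compound 3 (the limit leaves the size open), with a fair chance that this assay again reports only a limit. Compound 3 is estimated at 40000 nM, within 15000 nM to 100000 nM.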

Compound 3, half-maximal inhibitory concentration: > 40000 nM
Compound 3 was reported as a limit; the forecaster's own chance of this, stated with the estimate: 70%; the middle value sits exactly at the limit.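

In this assay compound 3 gives > 40000 nM, a limit and not a number. Compound 1 also stands at a limit, so no step can be read between compound 1 and compound 3: the limit of > 40000 nM in this assay, at which 2 of the 3 values shown sit.

The compounds shown leave open whether fluoro in place of hydrogen on an aromatic carbon changes the value at all in this assay.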